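Methoxy for Methyl on the Aryl Ring: Expected Toxicity

A few compounds are considered here, and "the series" means these few. Any claim that something is new, unique, unknown or untested is made for them only; others in the source may bear on it.

Of the compounds shown here, two sharing a common core have been tested in an ADME assay on Huh7.5.1 cells (Homo sapiens) for cytotoxicity, read by ATP content, with a stated time of 48 h; on this read-out lower numbers stand for higher toxicity in this test and higher numbers for lower toxicity in this test. Compound 1 `Cc1ccc(C)c(-c2nc(CN3CCC(C(=O)NCCCN4C[C@H](C)C[C@H](C)C4)CC3)c(C)o2)c1` gives in this assay a value of 4070 nM, the lower of the two numbers and therefore the more toxic of the pair in this test. Compound 2 `Cc1ccccc1-c1nc(CN2CCC(C(=O)NCCCN3CCC(C)(C)CC3)CC2)c(C)o1` gives in this assay a value of 10200 nM; since these two structures differ in more than one place, their gap cannot be tied to any single change.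

The untested compound 3 `COc1cccc(C)c1-c1nc(CN2CCC(C(=O)NCCCN3C[C@H](C)C[C@H](C)C3)CC2)c(C)o1` is built from compound 1 by one substitution on the shared core: 2-methoxy-6-methylphenyl in place of 2,5-dimethylphenyl on an aromatic carbon. Within the data shown here, no measured pair isolates a swap of this kind, so there is nothing in the data to point toward a larger or smaller number. The expectation is a step from compound 1 to compound 3 of a 1.1-fold higher number from compound 1 to compound 3 (0.04 log units; within the scatter), a movement that stays within the usual scatter and has no clear direction. Compound 3 is therefore estimated to show about 4500 nM, with a plausible range from 1800 nM to 11000 nM.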

Compound 3, half-maximal cytotoxic concentration: 16700 nM
Estimate against measurement, compound 3: 3.7-fold (0.57 log units) below; measured number above the stated range.
By their numbers in this assay, from the lowest: compound 1; then compounds 2 and 3 (each within the scatter of the next).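

Replacing the 2,5-dimethylphenyl of compound 1 with 2-methoxy-6-methylphenyl, with the rest of the molecule unchanged, gives a clear shift in this assay: a 4.1-fold higher number from compound 1 to compound 3 (0.61 log units; beyond the scatter), which means lower toxicity in this test. The earlier comparison could not show this because its two compounds differ in more than one place, whereas this pair ties a modest step to this aromatic carbon on the five-membered ring and to the group it carries. The entering group brings one more heavy atom, an oxygen, and one hydrogen-bond acceptor, but nothing available explains the shift.

This single swap alters the aryl ring in two ways at once, adding a methoxy group and changing the arrangement of the ring's substituents, so the compounds shown cannot separate the contribution of each. From the compounds shown here alone, it remains open whether a 2-ethoxy-6-methylphenyl or 2-chloro-6-methylphenyl group would move the number in the same direction, and whether the same swap would give a similar step with the 4,4-dimethylpiperidine chain end of compound 2.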